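The compounds below may be only part of what the source reports. "The series", "measured", "known", "first", "only" and "open" are said of these compounds alone.

Measured compounds:
compound 1 `COc1cc(-c2ccnc3cc(-c4ccc(F)cc4)nn23)cc(OC)c1OC`: 5030 nM
compound 2 `COc1cc(-c2ccnc3cc(-c4cccc(C)c4)nn23)cc(OC)c1OC`: 6150 nM

In a functional assay on HCT-116 cells (Homo sapiens) for inhibition, read by CCK-8 assay, with a stated time of 48 h (a lower number here means a stronger inhibitor, a higher number a weaker inhibitor), compound 1 gives 5030 nM and compound 2 gives 6150 nM. Compound 1 has the lowest of the two numbers, compound 2 the nearest, at a 1.2-fold higher number from compound 1 to compound 2 (0.09 log units; within the scatter). Compound 3 `COc1ccc(-c2cc3nccc(-c4cc(OC)c(OC)c(OC)c4)n3n2)cc1N` differs from compound 1 by 3-amino-4-methoxyphenyl in place of 4-fluorophenyl on an aromatic carbon. For the measured compounds named here, the only measured step, a 1.2-fold higher number from compound 1 to compound 2 (0.09 log units; within the scatter), also exchanges the ring on an aromatic carbon and stays within the scatter, so no step beyond the scatter is expected in either direction. Compound 3 is estimated at 4500 nM, between 1500 nM and 13000 nM. This estimate means a step of a 1.1-fold lower number from compound 1 to compound 3 (0.05 log units; within the scatter), expected to remain within the scatter.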

Compound 3, half-maximal inhibitory concentration: 251 nM
Compound 3: the middle estimate sits 18-fold (1.25 log units) above what was measured; the measured number lies below the stated range.
By their numbers in this assay, from the lowest: compound 3; then compounds 1 and 2 (each within the scatter of the next).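

In this assay the aromatic carbon of the five-membered ring proves sensitive to the ring it carries: 3-amino-4-methoxyphenyl gives a 20-fold lower number from compound 1 to compound 3 (1.30 log units; beyond the scatter) and also a 25-fold lower number from compound 2 to compound 3 (1.39 log units; beyond the scatter). The exchange between 4-fluorophenyl and 3-methylphenyl had shown no such movement, so that flat step does not hold for every ring at this position. No measurement at hand bears on the reason for the large steps.

Going by these compounds, the amino and methoxy groups enter together, so their separate shares remain open. A 3-aminophenyl or 4-methoxyphenyl ring, or a hydroxyl in place of the amine, would help separate them.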